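The compounds below may be only part of what the source reports. "The series", "measured", "known", "first", "only" and "open" are said of these compounds alone.

Of the compounds shown here, three share one core and have been measured in an assay on isolated protein for binding affinity to histone acetyltransferase KAT2B (Homo sapiens), read by isothermal titration calorimetry; a higher number here means weaker binding, a lower number tighter binding. Compound 1 `C=CCCn1c(N[C@@H]2C[C@H](c3ccccc3)CN(C)C2)nc2cc[nH]c2c1=O` gives 3410 nM; compound 2 `CN1C[C@H](Nc2nc3cc[nH]c3c(=O)n2C)C[C@H](c2ccccc2)C1` gives 152 nM; compound 3 `C=CCn1c(N[C@@H]2C[C@H](c3ccccc3)CN(C)C2)nc2cc[nH]c2c1=O` gives 676 nM. Compound 2 therefore stands lowest of the three, with compound 3 its nearest neighbour and compound 1 the furthest away. The measured steps are a 22-fold lower number from compound 1 to compound 2 (1.35 log units; beyond the scatter), a 5.0-fold lower number from compound 1 to compound 3 (0.70 log units; beyond the scatter) and a 4.4-fold higher number from compound 2 to compound 3 (0.65 log units; beyond the scatter); each of them alters the group on a saturated chain carbon bound to an aromatic nitrogen.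

Compound 4 `CN1C[C@H](Nc2nc3ccn(C)c3c(=O)n2C)C[C@H](c2ccccc2)C1` differs from compound 2 in another way: methyl in place of hydrogen on an aromatic nitrogen. Going by the values given here, no measured step touches this position, so the three steps above give no direct guide to its effect, and the expectation for compound 4 in this assay rests on the scatter alone, with wide bounds. The estimated result for compound 4 is 500 nM, within a range from 120 nM to 2500 nM. That estimate corresponds to an expected 3.3-fold higher number from compound 2 to compound 4 (0.52 log units; beyond the scatter).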

Compound 4, dissociation constant: > 10000 nM
Compound 4 was reported as a limit (the forecaster's own chance of this, stated with the estimate: 5%); middle value at least 20-fold (1.30 log units) from the limit.
By their numbers in this assay, from the lowest: compound 2; then compound 3; then compound 1. At a limit, above all of these: compound 4.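

In this assay, the hydrogen on this aromatic nitrogen proves far from neutral: putting methyl in its place, a change of one carbon, brings an at least 65-fold higher number from compound 2 to compound 4 (1.81 log units; beyond the scatter). The reading for compound 4 is a limit of the assay and not a number, so this step has a known minimum but no known full size: the limit of > 10000 nM in this assay, at which 1 of the 4 values shown sits. The earlier steps shown here touched only the group on a saturated chain carbon, and they gave no sign that this second position could matter so much, with even their largest step, a 22-fold lower number from compound 1 to compound 2 (1.35 log units; beyond the scatter), falling short of this one.

As far as these compounds go, whether the loss follows from removing the hydrogen or from the methyl that enters stays open. The compounds shown also do not tell how a longer chain such as ethyl, or a hydroxyethyl group, on this nitrogen would read.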